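This account rests on a few compounds, and the source may have more. Where it says the series, first, only, none or still open, it means among the compounds named here.

The measured compounds, in a physicochemical assay for acid dissociation:

compound 1, `COc1cccc(CNCCCNc2ccnc3cc(Cc4ccccc4)ccc23)c1O`, gives 9.47
compound 2, `COc1cccc(CNCCCNc2ccnc3cc(-c4ccc(C(F)(F)F)cc4)ccc23)c1O`, gives 9.47
compound 3, `COc1cccc(CNCCCNc2ccnc3cc(Oc4cccc(N(C)C)c4)ccc23)c1O`, gives 9.28

Compound 3 carries the smallest of the three numbers, but its separation from both others is within the scatter, so the three values are to be read as indistinguishable. The steps among them agree: no change at the digits printed from compound 1 to compound 2 (within the scatter), a number 0.19 log units lower from compound 1 to compound 3 (within the scatter), and a number 0.19 log units lower from compound 2 to compound 3 (within the scatter).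

Compound 4, `COc1cccc(CNCCCNc2ccnc3cc(Cc4cccc(C(F)(F)F)c4)ccc23)c1O`, is not yet measured. It differs from compound 3 in one place: 3-(trifluoromethyl)benzyl in place of 3-(dimethylamino)phenoxy on an aromatic carbon.

All three measured steps bear on this change, since each exchanges the group on the same aromatic carbon of the shared core, and none of them moved the number beyond the scatter. A fourth group at the same position is therefore expected to leave this assay unchanged beyond the scatter, with an expected step of a number 0.14 log units higher from compound 3 to compound 4 (within the scatter). Compound 4 is estimated at 9.42, with a range from 9.12 to 9.72.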

Compound 4, acid dissociation constant: 9.47
Beside the measured number, compound 4's estimate is 0.05 log units below it; the measured number falls inside the stated range.
By their numbers in this assay, from the lowest: compounds 3, 1, 2 and 4 (each within the scatter of the next).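

Trifluoromethyl in place of hydrogen on the benzyl group gave no change at the digits printed from compound 1 to compound 4 (within the scatter) in this assay, the only step here that adds to a group on this aromatic carbon rather than exchanging the whole group. With 3-(trifluoromethyl)benzyl in place of 3-(dimethylamino)phenoxy the result was a number 0.19 log units higher from compound 3 to compound 4 (within the scatter), and with 3-(trifluoromethyl)benzyl in place of 4-(trifluoromethyl)phenyl it was no change at the digits printed from compound 2 to compound 4 (within the scatter), so all four groups remain indistinguishable in this assay. No independent data bear on why the number stays within the scatter.

All four groups carry a six-membered aromatic ring of carbon only, so the compounds shown leave open whether a carboxylic acid or a primary amine on this carbon would also stay within the scatter. Going by these compounds, how a longer chain in the shared core would read in this assay also remains open.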